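The source may hold more compounds than are shown below. What is called first, only, known or untested is meant among the compounds shown, and "the series" means these compounds.

In a functional assay on NCI-H460 cells (Homo sapiens) for inhibition, read by sulforhodamine B assay, with a stated time of 48 h (a lower number here means a stronger inhibitor of growth, a higher number a weaker inhibitor of growth), three compounds have been measured so far. Compound 1 `COc1ccc(/C=C/C2CC(=O)C=CO2)cc1OC` gives 89.6 uM. Compound 2 `COc1cc(/C=C/C2CC(=O)C=CO2)cc(OC)c1OC` gives 127 uM, and compound 3 `O=C1C=CCC(/C=C/c2ccccc2C(F)(F)F)O1` gives 242 uM. Compound 2 thus stands second highest of the three numbers; its nearest neighbour is compound 1, and its furthest is compound 3, with both gaps within the scatter. Among the measured compounds shown here, the one step between measured compounds, a 1.4-fold higher number from compound 1 to compound 2 (0.15 log units; within the scatter), is a methoxy in place of hydrogen on an aromatic carbon and also lies within the scatter.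

The account now turns to compound 4 `COc1cc(/C=C/C2CC=CC(=O)O2)cc(OC)c1OC`, not yet measured. It differs from compound 2 in one place: a group of 7 heavy atoms (5 carbon, 2 oxygen; one six-membered non-aromatic ring with 1 hetero atom) in place of a group of 7 heavy atoms (5 carbon, 2 oxygen; one six-membered non-aromatic ring with 1 hetero atom), on a double-bonded chain carbon bound to a double-bonded chain carbon. The two compounds share the same atoms, joined differently.

For the measured compounds named here, no measured step bears on this change: the single step in hand concerns a methoxy group on an aromatic carbon and says nothing about rearranging the six-membered non-aromatic ring sitting on a double-bonded chain carbon. With nothing pointing in either direction, the step expected in this assay, a 1.0-fold higher number from compound 2 to compound 4 (0.01 log units; within the scatter), amounts to none beyond the scatter. Compound 4 is therefore estimated at 130 uM, with a range from 45 uM to 380 uM to reflect the absence of any guiding step.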

Compound 4, concentration for growth inhibition (reported as GI): 28.8 uM
For compound 4 the middle estimate is 4.5-fold (0.65 log units) above the measured one, and the stated range ends above it.
By their numbers in this assay, from the lowest: compound 4; then compounds 1, 2 and 3 (each within the scatter of the next, the first and the last beyond it).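

In this assay, among the compounds shown here, the change a 4.4-fold lower number from compound 2 to compound 4 (0.64 log units; beyond the scatter) is a rearrangement of the same atoms within the six-membered non-aromatic ring, on a double-bonded chain carbon bound to a double-bonded chain carbon, and it is the only step in hand that lies beyond the scatter. For the compounds shown here, the earlier compounds offered only a methoxy in place of hydrogen on an aromatic carbon, a step within the scatter, so this result is the first sign that the number responds to how the ring is joined, even though the heavy atoms, the double bonds outside aromatic rings and the hydrogen-bond acceptors are counted the same on both sides. Nothing available explains why this rearrangement lowers the number.

The compounds shown leave open whether the same rearrangement would lower the number with the aromatic substitution of compound 1 or compound 3. They also leave open how the number would respond to an amine on an aromatic carbon, or to a longer chain carrying the ring of compound 4.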